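Working notes: from compound 3 to compound 4

A few compounds are considered here, and "the series" means these few. Any claim that something is new, unique, unknown or untested is made for them only; others in the source may bear on it.

Measured in a functional assay on PC-3 cells (Homo sapiens) for inhibition, read by sulforhodamine B assay, with a stated time of 72 h; on this read-out lower numbers stand for stronger inhibition and higher numbers for weaker inhibition:
- compound 1 `Nc1sc(-c2ccc(Cl)cc2)c(-c2ccc(Cl)cc2)c1C(=O)N1CCCCC1=O`: 4940 nM
- compound 2 `CC1CCN(C(=O)c2c(N)sc(-c3ccc(Cl)cc3)c2-c2ccc(Cl)cc2)CC1`: 5750 nM
- compound 3 `Nc1sc(-c2ccc(Cl)cc2)c(-c2ccc(Cl)cc2)c1C(=O)N1CCCC1`: 6220 nM

The three measured compounds share a core and differ only in the ring on the carbonyl carbon. Compound 3 stands at 6220 nM, and this number is not separated from the other two. The nearest comparison is a 1.1-fold higher number from compound 2 to compound 3 (0.03 log units; within the scatter), and the furthest is a 1.3-fold higher number from compound 1 to compound 3 (0.10 log units; within the scatter).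

The next compound is compound 4 `Nc1sc(-c2ccc(Cl)cc2)c(-c2ccc(Cl)cc2)c1C(=O)N1CCNCC1`, which has piperazin-1-yl in place of pyrrolidin-1-yl on a carbonyl carbon.

All three measured steps are changes at this same place. Besides the two above, there is a 1.2-fold higher number from compound 1 to compound 2 (0.07 log units; within the scatter). Each of them stays within the scatter, so the ring has not yet moved the number in this assay across these three compounds. On that basis, no step beyond the scatter is expected, and no direction is favoured with any confidence.

Within the data shown here, none of the measured compounds carries piperazin-1-yl, so the new ring is untested here and the range is kept wide. The expected step is a 1.1-fold lower number from compound 3 to compound 4 (0.05 log units; within the scatter). For compound 4 the estimated value is 5500 nM, with an expected range of 2200 nM to 14000 nM.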

Compound 4, half-maximal inhibitory concentration: 2710 nM
Beside the measured number, compound 4's estimate is 2.0-fold (0.31 log units) above it; the measured number falls inside the stated range.
By their numbers in this assay, from the lowest: compounds 4, 1, 2 and 3 (each within the scatter of the next, the first and the last beyond it).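

In this assay, among these compounds, the ring on the carbonyl carbon now moves the number beyond the scatter, which no earlier step did: a 2.3-fold lower number from compound 3 to compound 4 (0.36 log units; beyond the scatter) and a 2.1-fold lower number from compound 2 to compound 4 (0.33 log units; beyond the scatter) are both modest steps. The effect does not hold against every ring in the series, since a 1.8-fold lower number from compound 1 to compound 4 (0.26 log units; within the scatter) does not separate the two, so the 2-oxopiperidin-1-yl amide goes against any reading of piperazin-1-yl as better than all the other rings. Piperazin-1-yl brings a hydrogen-bond donor and a hydrogen-bond acceptor that pyrrolidin-1-yl lacks, but these are only counted differences, and no supporting data are available to explain the step.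

On these data alone, it remains open whether the second ring nitrogen or its hydrogen carries the step, and morpholin-4-yl or 4-methylpiperazin-1-yl on the same carbonyl carbon would separate those two readings. Also open, as far as these compounds go, is whether the step survives on a longer chain, such as a 2-aminoethyl amine on that carbonyl carbon in place of the ring, and whether it reaches beyond this single cell line.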